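Shortening the Side Chain of Compound 2

The source may hold more compounds than are shown below. What is called first, only, known or untested is meant among the compounds shown, and "the series" means these compounds.

Measured so far:
compound 1, `CCC(C(=O)N1CCN(c2ccccc2F)CC1)N1C(=O)CCC1=O`: 100%
compound 2, `CCC(C(=O)N1CCOCC1)N1C(=O)CCC1=O`: 0%

The read-out comes from a functional assay on the whole organism (strain Swiss) with Mus musculus as the target, in the maximal electroshock model, with a stated time of 0.5 h, at a dose of 300 mg/kg by the intraperitoneal route; a lower number here means a weaker effect, a higher number a stronger effect of the compound at the dose given. In this assay compound 1 gives 100%, while compound 2 gives 0%, the lowest of the two numbers and a gap beyond the usual scatter. These two compounds differ in more than one place, so nothing can be said about what each difference contributes; their values simply stand as they are.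

Compound 3, `CC(C(=O)N1CCOCC1)N1C(=O)CCC1=O`, is compound 2 with a single change: hydrogen in place of methyl on a saturated chain carbon, two bonds along the chain from an amide-type nitrogen in a ring and a carbonyl carbon. A methyl leaves and a hydrogen takes its place. Among the compounds with values here, no measured pair shows what this change does here. Compound 2 already stands at 0%, the bottom of the scale, and so small a change gives no reason to expect a rise; the expected step is a number 5 percentage points higher from compound 2 to compound 3 (within the scatter), none beyond the scatter. Compound 3 is therefore estimated at 5%, with a likely range from 0% to 30%.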

Compound 3, a percentage reported as activity, at one dose (the size of the read-out at that dose, not a potency): 0%
Estimate against measurement, compound 3: 5 percentage points above; low and high end bracket the measured number.
By their numbers in this assay, from the lowest: compounds 2 and 3 (each within the scatter of the next); then compound 1.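

In this assay, the change from methyl to hydrogen on this saturated chain carbon, which can also be read as ethyl to methyl, gives no change at the digits printed from compound 2 to compound 3 (within the scatter). Within the data shown here, this is the first pair differing in one place, but both compounds sit at the bottom of the scale, so it shows only that this change brings no activity to this compound, not whether the methyl matters in a compound with activity to lose. No available data speak to the reason for this result.

From the compounds shown here alone, it remains open whether the same change would alter the read-out in compound 1, which gives 100% and so has room to fall. Also open, going by these compounds, is what a propyl chain, an amine or a carboxylic acid in place of the methyl would do.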